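From compound 2 to compound 3

The source may hold more compounds than are shown below. What is called first, only, known or untested is meant among the compounds shown, and "the series" means these compounds.

Measured so far in a physicochemical assay for solubility, read by spectrophotometry (on this read-out lower numbers stand for lower solubility and higher numbers for higher solubility), for two compounds
compound 1 `O=C(Nc1ccc(C(F)(F)F)cc1)c1cc(Cl)ccc1O` gives < 100000 nM
compound 2 `O=C(Nc1ccc(Cl)c(Cl)c1)c1cc(Br)ccc1O` gives < 100000 nM

Compound 2 stands at < 100000 nM and that is a limit of the assay, not a number. The two readings share one boundary, the limit of < 100000 nM in this assay, at which 2 of the 2 values shown sit, and neither compound can be placed against the other.

Compound 3 `O=C(NCCCCl)Oc1ccc(Br)cc1C(=O)Nc1ccc(Cl)c(Cl)c1` keeps the core of compound 2 and takes (3-chloropropyl)carbamoyl in place of hydrogen on an oxygen on an aromatic ring. In other words, hydroxy gives way to ((3-chloropropyl)carbamoyl)oxy. Going by the values given here, no two measured compounds differ in one place, so the data hold no step that sizes this change. The expectation in this assay is therefore for no step beyond the usual scatter, with at most a slight lean downward. Put as an estimate, the expected change is a step that the limit leaves unreadable from compound 2 to compound 3 and it stays small. Another limit instead of a number is expected to be quite possible. For compound 3 the estimated solubility is 50000 nM (expected range 10000 nM to 100000 nM).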

Compound 3, solubility: < 50000 nM
Compound 3 ended at the assay's limit; the forecaster's own chance of this, stated with the estimate: 65%; the middle value lies on the limit itself.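

In this assay, compound 2 gives < 100000 nM, which is a limit of the assay. Going by these compounds alone, compound 3 gives < 50000 nM, which is also a limit, so no step from compound 2 to compound 3 can be read. The compounds shown leave open how the solubility of compound 3 compares with that of compound 2.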